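Series notes: methoxy in place of methyl on compound 3

This account rests on a few compounds, and the source may have more. Where it says the series, first, only, none or still open, it means among the compounds named here.

Compound 3 `Cc1ccc2nc(C(=O)Nc3c(F)cc(-c4cccc(F)c4)cc3F)c(C)c(C(=O)O)c2c1` gives 35.6% in a functional assay on Hep 3B2 cells (Homo sapiens) for antiproliferative activity, read by MTT assay, with a stated time of 24 h, tested at 11.11 ug/mL; on this read-out lower numbers stand for a weaker effect and higher numbers for a stronger effect at the one concentration tested. Among the three compounds measured, compound 3 stands second highest: compound 2 `Cc1c(C(=O)Nc2c(F)cc(-c3cccc(F)c3)cc2F)nc2ccc(OC(F)(F)F)cc2c1O` gives 37.9%, which lies within the scatter of compound 3, while compound 1 `Cc1ccc2nc(C(=O)Nc3c(F)cc(-c4cccc(F)c4)cc3F)c(C)c(O)c2c1` gives 25.5%, and the step of a number 10.1 percentage points higher from compound 1 to compound 3 (beyond the scatter) is beyond the scatter. Compound 4 `COc1ccc2nc(C(=O)Nc3c(F)cc(-c4cccc(F)c4)cc3F)c(C)c(C(=O)O)c2c1` has not yet been measured. It differs from compound 3 by methoxy in place of methyl on an aromatic carbon. For the measured compounds named here, two measured steps bear on this. One is also a replacement of methyl on an aromatic carbon, trifluoromethoxy in place of methyl, which gave a number 12.4 percentage points higher from compound 1 to compound 2 (beyond the scatter). The other, carboxy in place of hydroxy on an aromatic carbon, gave a number 10.1 percentage points higher from compound 1 to compound 3 (beyond the scatter); compound 4 keeps the carboxy of compound 3, so that step fixes the starting point rather than the change. Going by the values given here, no measured pair shows methoxy itself, and trifluoromethoxy is a different group, so a step smaller than the trifluoromethoxy one is expected, possibly none beyond the scatter, with the direction upward if anything. In this assay compound 4 is expected to give 40%, in the range 28% to 52%. This estimate corresponds to an expected step of a number 4.4 percentage points higher from compound 3 to compound 4 (within the scatter).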

Compound 4, a percentage reported as inhibition, at one concentration (the size of the read-out at that concentration, not a potency): 2.34%
Estimate against measurement, compound 4: 37.7 percentage points above; measured number below the stated range.
By their numbers in this assay, from the lowest: compound 4; then compound 1; then compounds 3 and 2 (each within the scatter of the next).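

In this assay methoxy in place of methyl on an aromatic carbon gives a number 33.3 percentage points lower from compound 3 to compound 4 (beyond the scatter) and brings compound 4 to the bottom of the four compounds, so this carbon is sensitive to the group it carries. The earlier replacement of the same methyl, trifluoromethoxy on the hydroxy-bearing compound 1, gives a number 12.4 percentage points higher from compound 1 to compound 2 (beyond the scatter) and runs the other way, so a change at this carbon can move the number in either direction, and an oxygen attached there does not alone fix the sign. Nothing measured on these compounds accounts for the size of the step.

The two steps differ both in the entering group and in the hydroxy or carboxy elsewhere on the core, so the reversal cannot yet be assigned to either difference; methoxy on the hydroxy-bearing compound 1 and trifluoromethoxy on the carboxy-bearing compound 3 would separate the two. Also open, on these data alone, is how this carbon responds to a group without an attached oxygen, such as an amine or a chlorine atom, or to a longer chain such as ethoxy.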